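Side-chain ether to plain pentan-3-yl on the amine

A few compounds are considered here, and "the series" means these few. Any claim that something is new, unique, unknown or untested is made for them only; others in the source may bear on it.

Compound 1 `CCCCN(CC)c1nc(C)nc2c1c(C)nn2-c1c(C)cc(C)cc1C` gives 9 nM in a functional assay on CHO cells for antagonist activity at corticotropin-releasing factor receptor 1 (Homo sapiens), read by cAMP accumulation (on this read-out higher numbers stand for weaker inhibition and lower numbers for stronger inhibition), the lowest of the three numbers. Compound 2 `CCCNCc1nnc(Nc2nc(C)nc3c2c(C)nn3-c2ccc(OC)cc2C)o1` gives 996 nM in this assay, the highest. Compound 3 `CC[C@@H](COC)Nc1nc(C)nc2c1c(C)nn2-c1ccc(OC)cc1C` gives 135 nM in this assay and stands second highest, between compound 2 and compound 1. The step of a 7.4-fold lower number from compound 2 to compound 3 (0.87 log units; beyond the scatter) is the only one measured on this nitrogen and it swaps a ring-bearing group for an open chain.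

Compound 4 `CCC(CC)Nc1nc(C)nc2c1c(C)nn2-c1ccc(OC)cc1C` differs from compound 3 by pentan-3-yl in place of 1-(methoxymethyl)propyl on a nitrogen on an aromatic ring. Within the data shown here, no measured step exchanges one open-chain group on this nitrogen for another; the step from compound 2 to compound 3 swaps an oxadiazole for an open chain and does not match. Compound 1 carries only carbon on its amine and gives the lowest number, but differs in several places, so it is no direct guide. The expectation is therefore a step within the scatter, a 1.5-fold lower number from compound 3 to compound 4 (0.18 log units; within the scatter), with perhaps a slight lowering. Compound 4 is estimated at 90 nM in this assay, expected within 30 nM to 300 nM.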

Compound 4, inhibition constant: 42 nM
Beside the measured number, compound 4's estimate is 2.1-fold (0.33 log units) above it; the range from low to high includes it.
By their numbers in this assay, from the lowest: compound 1; then compound 4; then compound 3; then compound 2.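

On a nitrogen on an aromatic ring, pentan-3-yl in place of 1-(methoxymethyl)propyl gives a 3.2-fold lower number from compound 3 to compound 4 (0.51 log units; beyond the scatter) in this assay, so an exchange between two open-chain groups at this position moves the number beyond the scatter. Set against the ring-bearing 5-((propylamino)methyl)-1,3,4-oxadiazol-2-yl, pentan-3-yl gives a 24-fold lower number from compound 2 to compound 4 (1.38 log units; beyond the scatter), so the three groups on this nitrogen now stand in order, with the all-carbon chain lowest. No supporting data bear on why the chain without the ether oxygen gives the lower number.

Open, going by these compounds, is whether a cyclopentyl group, a longer chain or a chain ending in a hydroxyl on this nitrogen would keep this order. Also open, on these data alone, is how a second carbon chain on this nitrogen, as in compound 1, would act on the core of compound 4, since compound 1 differs from it in more than one place.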